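Imidazolyl to Dimethylamino on a Propargylic Carbon

The source may report more compounds than this note shows. Statements on the series, on what has been measured and on what is new or still open speak of the compounds shown alone.

Compound 1 `CC(C#CCn1ccnc1)N1CCCC1=O` and compound 2 `CC(C#CCN(C)C)N1CCCC1=O` share a core and differ only at the group on a saturated chain carbon bound to a triple-bonded carbon, as counted in dimethylamino in place of 1H-imidazol-1-yl on a saturated chain carbon bound to a triple-bonded carbon. In a functional assay on the whole organism for agonist activity, with Mus musculus as the target (on this read-out lower numbers stand for an effect already at smaller amounts and higher numbers for an effect only at larger amounts of compound), compound 1 gives > 100 mg/kg, which is a limit of the assay and not a number. In this assay compound 2 gives 100 mg/kg. The step of a number no higher from compound 1 to compound 2 (the limit leaves the size open) is therefore open-ended, because the starting value sits at the limit of > 100 mg/kg in this assay, at which 1 of the 3 values shown sits.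

Compound 3 `COC(=O)N(C)C(C)C#CCn1ccnc1` carries a different core; how it differs from the core of compound 1 is not broken down here. In this assay compound 3 gives 6.6 mg/kg, the lowest of the two numbers shown, with compound 2 the nearest at a distance beyond the usual scatter.

Compound 4 `COC(=O)N(C)C(C)C#CCN(C)C` is compound 3 with the change (dimethylamino in place of 1H-imidazol-1-yl on a saturated chain carbon bound to a triple-bonded carbon), the same change that leads from compound 1 to compound 2. On these data alone, because the measured step of a number no higher from compound 1 to compound 2 (the limit leaves the size open) only shows that the number did not rise, its size remains open, and the expected step of a 1.1-fold higher number from compound 3 to compound 4 (0.03 log units; within the scatter) is taken to be small. On that basis compound 4 is expected to give about 7 mg/kg in this assay, with a range from 2 mg/kg to 30 mg/kg as the estimate.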

Compound 4, dose for half-maximal effect: 11.8 mg/kg
The estimate for compound 4 lay 1.7-fold (0.23 log units) below the measured number; low and high end bracket the measured number.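

In this assay, putting dimethylamino in place of 1H-imidazol-1-yl on the core of compound 3 gives a 1.8-fold higher number from compound 3 to compound 4 (0.25 log units; within the scatter), so on this core the read-out does not separate the two groups. Set beside the same change on the core of compound 1, the comparison stays unsettled: the same change on two cores in this assay, a number no higher (the limit leaves the size open) from compound 1 to compound 2 and a 1.8-fold higher number (0.25 log units; within the scatter) from compound 3 to compound 4; the limit leaves it open whether they differ. Compound 1 gives > 100 mg/kg, which is a limit of the assay and not a number, so the step on that core cannot be read, and the two compounds pairs show neither that the change carries over from one core to the other with the same size nor that it does not.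

The compounds shown leave open how another amine, such as diethylamino or pyrrolidin-1-yl, would read on a saturated chain carbon bound to a triple-bonded carbon, on either core. They also leave open whether the change keeps its size on a further core, where both partners of the pair would give a number and the two steps could be compared directly.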